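Propyl in place of vinyl at the double-bonded nitrogen

This account rests on a few compounds, and the source may have more. Where it says the series, first, only, none or still open, it means among the compounds named here.

Compounds measured so far:
compound 1, `CC/N=c1/c(C#N)c2n(c(=O)n1-c1ccccc1)CCC2` — 7.82%
compound 2, `C=CC/N=c1/c(C#N)c2n(c(=O)n1-c1ccccc1)CCC2` — 2.23%

In a functional assay on the whole organism (strain albino) for inhibition, with Rattus norvegicus as the target, read by paw edema, with a stated time of 1 h, at a dose of 0.029 mmol/kg by the oral route (on this read-out lower numbers stand for less inhibition and higher numbers for more inhibition at the one dose given (going by the name of the read-out)), compound 1 gives 7.82%, and compound 2 gives 2.23%. Going by the values given here, the one step between them, a number 5.6 percentage points lower from compound 1 to compound 2 (within the scatter), is within the scatter, so compound 2 stands as the lower of the two numbers without that telling anything about a real difference from compound 1. Both numbers are small in this assay.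

Compound 3, `CCCC/N=c1/c(C#N)c2n(c(=O)n1-c1ccccc1)CCC2`, is not yet measured. It differs from compound 2 by propyl in place of vinyl on a saturated chain carbon bound to a double-bonded nitrogen. Among the compounds with values here, the only step that bears on this change is the one from compound 1 to compound 2, where methyl became vinyl at the same saturated chain carbon bound to a double-bonded nitrogen, and that step stayed within the scatter. A propyl group in place of vinyl at that carbon is a change of the same kind at the same place, and nothing among the two measured compounds points to a shift beyond the scatter. Compound 3 is therefore expected to sit close to compound 2, with a step of a number 3.8 percentage points higher from compound 2 to compound 3 (within the scatter). The estimate for compound 3 in this assay is 6%, within a range from -6% to 18%.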

Compound 3, a percentage reported as inhibition, in the whole organism at one dose (the size of the read-out at that dose, not a potency): 11.2%
For compound 3 the middle estimate is 5.2 percentage points below the measured one, and the stated range covers the measured number.
By their numbers in this assay, from the lowest: compounds 2, 1 and 3 (each within the scatter of the next).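

In this assay, propyl in place of vinyl on a saturated chain carbon bound to a double-bonded nitrogen gives a number 9 percentage points higher from compound 2 to compound 3 (within the scatter), and ethyl in place of hydrogen on a saturated chain carbon, two bonds along the chain from a double-bonded nitrogen, gives a number 3.4 percentage points higher from compound 1 to compound 3 (within the scatter). The earlier compounds had shown only one change at this place, whereas the three compounds now show that neither removing the double bond from the allyl group nor extending the chain to butyl separates them beyond the scatter in this assay. No independent measurement bears on this result, so nothing can be said about what lies behind these numbers.

Still open, as far as these compounds go, is whether an amine or a carboxylic acid at the end of this chain, or a chain longer than butyl, would give a step beyond the scatter. Also open, from the compounds shown here alone, is whether these compounds differ under other conditions, since the numbers here come from a single oral dose and a single stated time.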